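A few compounds are considered here, and "the series" means these few. Any claim that something is new, unique, unknown or untested is made for them only; others in the source may bear on it.

In a functional assay on the whole organism with Rattus norvegicus as the target, read by paw edema, with a stated time of 3 h, at a dose of 100 mg/kg by the oral route (on this read-out higher numbers stand for more inhibition at the one dose given (going by the name of the read-out) and lower numbers for less inhibition), compound 1, `COc1ccc2[nH]c(-c3cccc(C)n3)nc2c1`, gives 40%. Compound 2, `Cc1cccc(-c2nc3cc(O)ccc3[nH]2)n1`, carries the change (hydrogen in place of methyl on an oxygen on an aromatic ring), and in this assay compound 2 gives 6%, so that the step is a number 34 percentage points lower from compound 1 to compound 2 (beyond the scatter). Compound 3, `COc1cccc(-c2nc3cc(C)ccc3[nH]2)n1`, is built from the same atoms as compound 1 joined differently; how the two cores differ is not broken down here. In this assay compound 3 gives 32%, which lies within the scatter of the value of compound 1 and beyond the scatter from that of compound 2. Compound 4, `Cc1ccc2[nH]c(-c3cccc(O)n3)nc2c1`, has not yet been measured. It differs from compound 3 by hydrogen in place of methyl on an oxygen on an aromatic ring, the same change as that from compound 1 to compound 2, at a place described in the same words. For the measured compounds named here, only one earlier example of this change is known, and it lies in a single pair. The estimated step is a number 27 percentage points lower from compound 3 to compound 4 (beyond the scatter), which rests on a number 34 percentage points lower from compound 1 to compound 2 (beyond the scatter). Compound 4 is therefore expected to give about 5%, plausibly between 0% and 20%.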

Compound 4, a percentage reported as inhibition, in the whole organism at one dose (the size of the read-out at that dose, not a potency): -6%
Compound 4: middle estimate off by 11 percentage points, on the high side; measured number outside the range, below it.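

In this assay, methoxy to hydroxy again brings a large drop on the second core, with a number 38 percentage points lower from compound 3 to compound 4 (beyond the scatter). Set beside the earlier step, the new one shows no real difference in size: the same change on two cores in this assay, a number 34 percentage points lower (beyond the scatter) from compound 1 to compound 2 and a number 38 percentage points lower (beyond the scatter) from compound 3 to compound 4, 4 percentage points apart, within the scatter of two such steps. For the compounds shown here, the change therefore carried over with its size intact between these two cores, but this rests on only two pairs and does not show why the number falls or whether the step would hold on any other core.

The compounds shown leave open what other groups on that oxygen, such as an ethyl or a longer chain, would give, and whether an amine or a carboxylic acid in place of the hydroxy would give a similarly low reading. They also leave open whether the same step would appear at another dose or time, since every reading here comes from a single dose and a single time.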